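Phenyl to Furan on the Ketone of a Weak Cytotoxic Series

The source may report more compounds than this note shows. Statements on the series, on what has been measured and on what is new or still open speak of the compounds shown alone.

Compound 1, `COc1cc(C(=O)C2Sc3nnc(-c4cc(OC)c(OC)c(OC)c4)n3NC2c2cccs2)cc(OC)c1OC`: > 100000 nM
Compound 2, `COc1cc(-c2nnc3n2NC(c2ccco2)C(C(=O)c2ccccc2)S3)cc(OC)c1OC`: 64300 nM

Two compounds built on the same core have been run in a functional assay on PC-3 cells (Homo sapiens) for cytotoxicity, read by MTT assay, with a stated time of 48 h; on this read-out higher numbers stand for weaker inhibition and lower numbers for stronger inhibition. Compound 1 `COc1cc(C(=O)C2Sc3nnc(-c4cc(OC)c(OC)c(OC)c4)n3NC2c2cccs2)cc(OC)c1OC` returns only a limit, > 100000 nM, so no number is known for it. Among the measured compounds shown here, compound 2 `COc1cc(-c2nnc3n2NC(c2ccco2)C(C(=O)c2ccccc2)S3)cc(OC)c1OC` gives 64300 nM, and this is the only real number in the set. The remaining entry, that of compound 1, is the limit of > 100000 nM in this assay, at which 1 of the 2 values shown sits. Compound 2 therefore stands alone as a measured point, with nothing to rank it against.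

Compound 3 `COc1cc(-c2nnc3n2NC(c2ccco2)C(C(=O)c2ccco2)S3)cc(OC)c1OC` has not been measured. It differs from compound 2 in one place: furan-2-yl in place of phenyl on a carbonyl carbon. For the measured compounds named here, no measured pair in the set shows this same change, so nothing here tells which way the value should move or how far. The expectation for the step of a 1.1-fold lower number from compound 2 to compound 3 (0.03 log units; within the scatter) is therefore a small one, not beyond the scatter of repeated measurements, and in no set direction. Compound 3 is estimated at 60000 nM, with a range from 25000 nM to 150000 nM.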

Compound 3, half-maximal inhibitory concentration: 58300 nM
Beside the measured number, compound 3's estimate is 1.0-fold (0.01 log units) above it; the range from low to high includes it.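

In this assay, among the compounds shown here, putting furan-2-yl in place of phenyl on a carbonyl carbon gives a 1.1-fold lower number from compound 2 to compound 3 (0.04 log units; within the scatter), the first measured step at this position. The swap exchanges a six-membered aromatic ring of carbon only for a five-membered aromatic ring holding one oxygen, a hydrogen-bond acceptor, and the read-out does not separate the two compounds. For the compounds shown here, at this position, then, this particular exchange of one aromatic ring for another leaves the cytotoxicity as measured where it was, which the earlier compounds alone could not show. Compound 1 gives only a limit and not a number, and it differs from the others in more than one place, so no step to it can be read: the limit of > 100000 nM in this assay, at which 1 of the 3 values shown sits.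

The compounds shown leave open whether something other than these two aromatic rings on the carbonyl carbon, such as an amine, a carboxylic acid or a longer chain, would move the number beyond the scatter. Also open, on these data alone, is whether a change elsewhere on the shared core would do what this swap does not and shift the value by more than the scatter.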